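The source may report more compounds than this note shows. Statements on the series, on what has been measured and on what is new or still open speak of the compounds shown alone.

Compound 1 `CC(C)C[C@H](N)c1cc(C(F)(F)F)ccc1N1CCN(C(=O)[C@H]2CSC[C@@H]2c2ccc(Cl)cc2)CC1` is the weaker of the two measured compounds in an assay on HEK293 cells for displacement of a labelled ligand from Melanocortin receptor 4 (Homo sapiens) (a higher number here means a weaker inhibitor, a lower number a stronger inhibitor), giving 280 nM. Compound 2 `CC(C)C[C@H](N)c1cc(C(F)(F)F)ccc1N1CCN(C(=O)[C@H]2CS(=O)(=O)C[C@@H]2c2ccc(Cl)cc2)CC1` gives 38 nM in this assay, a number beyond the scatter from that of compound 1. Compound 3 `CC(C)C[C@H](N)c1cc(C(F)(F)F)ccc1N1CCN(C(=O)[C@H]2CCO[C@@H]2c2ccc(Cl)cc2)CC1` is not yet measured; it differs from compound 1 by 2-(4-chlorophenyl)oxolan-3-yl in place of 4-(4-chlorophenyl)thiolan-3-yl on a carbonyl carbon, so both the ring hetero atom and the attachment of the chlorophenyl group on the five-membered ring change at once. Nothing measured resembles this change, so compound 3 is expected to stay near compound 1, with the step of a 1.4-fold higher number from compound 1 to compound 3 (0.15 log units; within the scatter) estimated within the scatter; its expected value is 400 nM with a range of 100 nM to 1600 nM.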

Compound 3, inhibition constant: 330 nM
Beside the measured number, compound 3's estimate is 1.2-fold (0.08 log units) above it; measured number inside the range.
By their numbers in this assay, from the lowest: compound 2; then compounds 1 and 3 (each within the scatter of the next).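

Replacing 4-(4-chlorophenyl)thiolan-3-yl with 2-(4-chlorophenyl)oxolan-3-yl on the carbonyl carbon gives, in this assay, a 1.2-fold higher number from compound 1 to compound 3 (0.07 log units; within the scatter). This position therefore accepts the ring oxygen and the moved chlorophenyl group together with no shift beyond the scatter, although the two changes are made at once and cannot be told apart. Nothing available explains this result.

The compounds shown leave open how each change acts alone, and whether an amine nitrogen in place of the ring oxygen would keep the number within the scatter.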